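Chain extension far from the aromatic ring: compound 2 to compound 3

This account rests on a few compounds, and the source may have more. Where it says the series, first, only, none or still open, it means among the compounds named here.

Measured so far:
Compound 1 `CCCCCCCCCCCCCCCCc1nc(N2CCC2)nc(OC2CCC2)c1O`: 114%
Compound 2 `CCCCCCCCCCCCCCc1nc(OC2CCC2)nc(OC2CCC2)c1O`: 98%

In a functional assay on cells (Lymphocyte, Homo sapiens), read by a luciferase reporter and ATP content, with a stated time of 48 h, tested at 5 uM (a lower number here means a stronger effect, a higher number a weaker effect of the compound at the concentration tested), compound 1 gives 114% and compound 2 gives 98%. Compound 2 stands lowest of the two numbers; its nearest neighbour is compound 1, whose number is higher by an amount beyond the usual scatter. Among the measured compounds shown here, the two compounds differ in more than one place, so the pair shows only that compound 2 reads lower; no single-point step between measured compounds is available in this assay.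

Compound 3 `CCCCCCCCCCCCCCCCc1nc(OC2CCC2)nc(OC2CCC2)c1O` is not yet measured. It differs from compound 2 in one place: ethyl in place of hydrogen on a saturated chain carbon, ten or more bonds along the chain from an aromatic carbon. The change leaves the saturated chain saturated and sits well away from the aromatic carbon. For the measured compounds named here, nothing among the measured compounds isolates this kind of change, so the expectation rests on the small nature of the alteration alone.

The step is expected to be a number 2 percentage points higher from compound 2 to compound 3 (within the scatter), a change within the scatter with no direction claimed. Compound 3 is therefore estimated at 100%, with a range from 85% to 118%.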

Compound 3, a percentage reported as activity, at one concentration (the size of the read-out at that concentration, not a potency): 102%
Estimate against measurement, compound 3: 2 percentage points below; the range from low to high includes it.
By their numbers in this assay, from the lowest: compounds 2 and 3 (each within the scatter of the next); then compound 1.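

In this assay, ethyl in place of hydrogen on a saturated chain carbon, ten or more bonds along the chain from an aromatic carbon, gives a step of a number 4 percentage points higher from compound 2 to compound 3 (within the scatter), so at this position and at the concentration tested, this extension produces no readable change. Cyclobutyloxy in place of azetidin-1-yl on an aromatic carbon gives the first single-place comparison at that carbon, a modest step of a number 12 percentage points lower from compound 1 to compound 3 (beyond the scatter), and of the two single-place steps now available, only this one lies beyond the scatter. Nothing at hand bears on the reason for the size of either step.

Still open, going by these compounds, is whether a longer chain or a carboxylic acid in that same place on the saturated chain would also leave the reading unchanged. Also open, on these data alone, is whether the step on the aromatic carbon extends to other groups there, such as a dimethylamino group or a methoxy group, and each reading here is taken at one concentration, so none of this describes potency.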